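The source may hold more compounds than are shown below. What is called first, only, known or untested is meant among the compounds shown, and "the series" means these compounds.

In a functional assay on HCT-15 cells (Homo sapiens) for antiproliferative activity, read by MTT assay, with a stated time of 72 h (a lower number here means a stronger inhibitor, a higher number a weaker inhibitor), compound 1 `COc1cc(-c2nccn2Cc2ccccc2)cc(OC)c1OC` gives > 100000 nM, which is a limit of the assay and not a number. Among the measured compounds shown here, compound 2 `COc1cc(-c2nccn2-c2ccc(C)cc2)cc(OC)c1OC` gives 800 nM, the only true number so far. For the measured compounds named here, putting 4-methylphenyl in place of benzyl on an aromatic nitrogen gave an at least 120-fold lower number from compound 1 to compound 2 (2.09 log units; beyond the scatter), a large change and the one measured step that bears on what comes next. Compound 3 `COc1cccc(-n2ccnc2-c2cc(OC)c(OC)c(OC)c2)c1` has 3-methoxyphenyl in place of 4-methylphenyl on that aromatic nitrogen (3-methoxyphenyl in place of 4-methylphenyl on an aromatic nitrogen). Both groups are a six-membered aromatic ring of carbon only, so a change as large as an at least 120-fold lower number from compound 1 to compound 2 (2.09 log units; beyond the scatter) is not expected for compound 3. One step cannot fix a direction, but a slightly higher number is the cautious expectation, with little or nothing beyond the scatter. The expected step is a 1.9-fold higher number from compound 2 to compound 3 (0.27 log units; within the scatter). For compound 3 the estimated value is 1500 nM, with an expected range of 300 nM to 8000 nM.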

Compound 3, half-maximal inhibitory concentration: 17100 nM
Beside the measured number, compound 3's estimate is 11-fold (1.06 log units) below it, outside the stated range (above it).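

In this assay, the choice of group on the aromatic nitrogen matters even between two six-membered aromatic rings of carbon only: 3-methoxyphenyl in place of 4-methylphenyl gave a 21-fold higher number from compound 2 to compound 3 (1.33 log units; beyond the scatter), so the step away from benzyl is not the only large one at this position. Having such a ring there is therefore not enough on its own to give the number of compound 2, although 3-methoxyphenyl in place of benzyl still gave an at least 5.8-fold lower number from compound 1 to compound 3 (0.76 log units; beyond the scatter). Compound 1 stands at a limit and not a number: the limit of > 100000 nM in this assay, at which 1 of the 3 values shown sits.

From the compounds shown here alone, what a 4-methoxyphenyl or a 3-methylphenyl group would give stays open, so the change of group cannot yet be separated from the change in where it sits on the ring. Also open, going by these compounds, is how an unsubstituted phenyl or a 3-aminophenyl group would compare.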